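A few compounds are considered here, and "the series" means these few. Any claim that something is new, unique, unknown or untested is made for them only; others in the source may bear on it.

Compound 1, `Nc1cccc(CNc2cc(C(F)(F)F)cc3[nH]ncc23)c1`: 89%
Compound 2, `O=[N+]([O-])c1cccc(CNc2cc(C(F)(F)F)cc3[nH]ncc23)c1`: 82%
Compound 3, `O=[N+]([O-])c1ccc(O)cc1CNc1cc(Br)cc2[nH]ncc12`: 99%

Of the compounds shown here, three share a core and have been tested in an assay for inhibition of Tryptophan 2,3-dioxygenase (Homo sapiens), with stated times of 10 min and 60 min, tested at 100 uM; on this read-out lower numbers stand for a weaker effect and higher numbers for a stronger effect at the one concentration tested. Compound 2 gives 82% in this assay. Against compound 1 its number sits within the usual scatter, so the two cannot be told apart, whereas compound 3 lies beyond the scatter above it; compound 3 differs from compound 2 in more than one place, so only the two values themselves can be compared there.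

Compound 4, `O=C(O)c1cccc(CNc2cc(C(F)(F)F)cc3[nH]ncc23)c1`, is not yet measured. It differs from compound 2 in one place: carboxy in place of nitro on an aromatic carbon.

Among the measured compounds shown here, only one measured step changes a group at this same position: a number 7 percentage points lower from compound 1 to compound 2 (within the scatter), a swap that stayed within the scatter. For the measured compounds named here, no step exchanges nitro for carboxy, so the expectation rests on that single comparison, which shows the number at this position tolerating one replacement without moving beyond the scatter. The expected step is therefore no change at the digits printed from compound 2 to compound 4 (within the scatter), with no change beyond the scatter foreseen in either direction. Compound 4 is accordingly estimated at 82% in this assay, with a likely range from 65% to 95%.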

Compound 4, a percentage reported as inhibition, at one concentration (the size of the read-out at that concentration, not a potency): 94%
Compound 4: the middle estimate sits 12 percentage points below what was measured, within the range that was stated.
By their numbers in this assay, from the lowest: compounds 2, 1, 4 and 3 (each within the scatter of the next, the first and the last beyond it).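

Among the compounds shown here, at this position, on an aromatic carbon meta to a large group, the earlier compounds showed only one swap, and it stayed within the scatter. In this assay, putting carboxy in place of nitro gives a number 12 percentage points higher from compound 2 to compound 4 (beyond the scatter), so the group here can move the read-out measurably, even though this step is modest and the two groups have the same number of heavy atoms and neither carries a ring or a net charge. Carboxy in place of amino gives a number 5 percentage points higher from compound 1 to compound 4 (within the scatter), so those two cannot be told apart, and only nitro and carboxy are separated at this position, while amino lies within the scatter of both.

The data shown offer no measurement that explains why carboxy and nitro differ here, including whether the hydrogen-bond donor that carboxy brings and nitro lacks plays any part. Also open, on these data alone, is how a methyl ester, a primary amide or a nitrile would read at this position, and whether a longer chain carrying the carboxy group would keep the number of compound 4.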